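A few compounds are considered here, and "the series" means these few. Any claim that something is new, unique, unknown or untested is made for them only; others in the source may bear on it.

Of the compounds shown here, three built on one shared core have been measured in an assay on membranes from brain for displacement of a labelled ligand from Neuronal acetylcholine receptor; alpha4/beta2 (Rattus norvegicus); a lower number here means a stronger inhibitor, a higher number a weaker inhibitor. Compound 1 `Cc1cncc(OC[C@@H]2CCCN2C)c1` gives 0.48 nM. Compound 2 `CCCc1cncc(OC[C@@H]2CCCN2C)c1` gives 0.12 nM. Compound 3 `CC(=O)c1cncc(OC[C@@H]2CCCN2C)c1` gives 1.19 nM, the highest of the three numbers and beyond the scatter from both of the others: the step of a 2.5-fold higher number from compound 1 to compound 3 (0.39 log units; beyond the scatter) and the step of a 9.9-fold higher number from compound 2 to compound 3 (1.00 log units; beyond the scatter) were both increases. Within the pair that carries only saturated chains, the step of a 4.0-fold lower number from compound 1 to compound 2 (0.60 log units; beyond the scatter) was a decrease when the chain was lengthened.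

Compound 4 `CN1CCC[C@H]1COc1cncc(C(=O)N2CCCC2)c1` differs from compound 3 by pyrrolidin-1-yl in place of methyl on a carbonyl carbon. Within the data shown here, none of the measured steps alters the group on the carbonyl carbon itself, so they bear on this change only loosely: lengthening a chain on the aromatic carbon lowered the number from compound 1 to compound 2, while the carbonyl-bearing compound 3 sits highest. A modest step in either direction, or none beyond the scatter, is therefore plausible, and the estimate leans toward little change. Compound 4 is expected to give about 2 nM, within 0.4 nM to 10 nM, a step of a 1.7-fold higher number from compound 3 to compound 4 (0.23 log units; within the scatter).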

Compound 4, inhibition constant: 19.9 nM
Compound 4: middle estimate off by 10-fold (1.00 log units), on the low side; measured number above the stated range.
By their numbers in this assay, from the lowest: compound 2; then compound 1; then compound 3; then compound 4.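

In this assay, among these compounds, the group on the carbonyl carbon turns out to matter a great deal, which the earlier compounds could not show because none of them changed it: pyrrolidin-1-yl in place of methyl there gives a large step, a 17-fold higher number from compound 3 to compound 4 (1.22 log units; beyond the scatter). Measured against the saturated chains on the aromatic carbon, (pyrrolidin-1-yl)carbonyl costs even more, with a 41-fold higher number from compound 1 to compound 4 (1.62 log units; beyond the scatter) and a 170-fold higher number from compound 2 to compound 4 (2.22 log units; beyond the scatter), which makes compound 4 the weakest of the four, beyond the scatter from each of the others. Nothing measured here explains the size of these steps.

As far as these compounds go, it remains open whether a smaller group on the carbonyl carbon, such as dimethylamino or the hydroxyl of a carboxylic acid, would read closer to compound 3 or to compound 4. From the compounds shown here alone, it is also open whether a larger ring, such as piperidin-1-yl, would push the number higher still.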